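The source may report more compounds than this note shows. Statements on the series, on what has been measured and on what is new or still open speak of the compounds shown alone.

Working notes on the series.

The shared core carries a trifluoromethoxy group; compound 1 `Cn1c(=N)sc2cc(OC(F)(F)F)ccc21` has the bare methyl on the aromatic nitrogen and in a functional assay on the whole organism with Rattus norvegicus as the target (on this read-out higher numbers stand for an effect only at larger amounts of compound and lower numbers for an effect already at smaller amounts), compound 1 gives 5 mg/kg. Compound 2 `CCCCn1c(=N)sc2cc(OC(F)(F)F)ccc21` extends that substituent, and in this assay compound 2 gives 10 mg/kg, the highest of the two numbers shown, though the step of a 2.0-fold higher number from compound 1 to compound 2 (0.30 log units; within the scatter) stays within the scatter. Compound 3 `COC(=O)Cn1c(=N)sc2cc(OC(F)(F)F)ccc21` reaches only a limit of the read-out in this assay, > 10 mg/kg, so the step of an at least 2.0-fold higher number from compound 1 to compound 3 (0.30 log units; that floor lies within the scatter) has a floor but no fixed size, as noted in the limit of > 10 mg/kg in this assay, at which 1 of the 3 values shown sits.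

Compound 4 `N=c1sc2cc(OC(F)(F)F)ccc2n1CC[S+]([O-])c1ccccc1` is the next candidate. Its difference from compound 2 is a group of 8 heavy atoms (6 carbon, 1 oxygen, 1 sulfur; one six-membered aromatic ring of carbon only) in place of a group of 2 heavy atoms (2 carbon; no ring), on a saturated chain carbon, two bonds along the chain from an aromatic nitrogen. The change sits on the same chain, one bond further along than the steps already measured; those steps are a 2.0-fold higher number from compound 1 to compound 2 (0.30 log units; within the scatter) and a number no lower from compound 2 to compound 3 (the limit leaves the size open), and neither resolves a clear direction beyond the scatter. A large group entering on the chain is the case of compound 3, which gave only a limit. The expectation for compound 4 in this assay is therefore a number near that of compound 2 or somewhat higher, with a real chance of another limit: the estimated step is a 1.5-fold higher number from compound 2 to compound 4 (0.18 log units; within the scatter), and compound 4 is expected at 15 mg/kg, within a range of 5 mg/kg to 40 mg/kg.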

Compound 4, dose for half-maximal effect: 4.2 mg/kg
The estimate for compound 4 lay 3.6-fold (0.55 log units) above the measured number; measured number below the stated range.
By their numbers in this assay, from the lowest: compounds 4, 1 and 2 (each within the scatter of the next, the first and the last beyond it).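

In this assay, going by these compounds alone, the entry of the group of 8 heavy atoms, with its six-membered aromatic ring of carbon only, in place of ethyl on a saturated chain carbon, two bonds along the chain from an aromatic nitrogen, gives a 2.4-fold lower number from compound 2 to compound 4 (0.38 log units; beyond the scatter), the first step that has a readable size and lies beyond the scatter. Within the data shown here, a large group on this chain therefore need not push the number upward, and at this place the change runs towards a lower number, a direction the earlier steps did not resolve. Among these compounds, nothing measured so far bears on why the number moves this way.

The compounds shown leave open which part of the entering group carries the step, the aromatic ring, the sulfur or its oxygen; a sulfone, a thioether or a plain phenyl on the same chain would separate these parts. Also open is whether the lower number extends to other kinds of group on the chain, such as an amine or a carboxylic acid, and of compound 3 only a limit is known: the limit of > 10 mg/kg in this assay, at which 1 of the 4 values shown sits.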